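The source may report more compounds than this note shows. Statements on the series, on what has been measured and on what is new or still open speak of the compounds shown alone.

Working notes on the series. Compound 1 `CC1(C)S[C@@H]2/C(=C\C(=O)c3ccco3)C(=O)N2[C@H]1C(=O)OC(c1ccccc1)c1ccccc1` and compound 2 `CC1(C)S[C@@H]2/C(=C\C(=O)OC(c3ccccc3)c3ccccc3)C(=O)N2[C@H]1C(=O)OC(c1ccccc1)c1ccccc1` have both been run in a functional assay on HT-1080 cells (Homo sapiens) for cytotoxicity, read by MTT assay, with a stated time of 48 h; a higher number here means a weaker inhibitor, a lower number a stronger inhibitor; in this assay compound 1 gives 45500 nM and compound 2 gives 15200 nM. Compound 1 thus carries the higher of the two numbers, and the gap to compound 2 lies beyond the usual scatter. Compound 3 `CC(=O)/C=C1/C(=O)N2[C@@H]1SC(C)(C)[C@@H]2C(=O)OC(c1ccccc1)c1ccccc1` has not yet been measured in this assay. It differs from compound 1 in one place: methyl in place of furan-2-yl on a carbonyl carbon, the same difference read one bond further out being (furan-2-yl)carbonyl to acetyl. Within the data shown here, no step between measured compounds matches this change, so the direction rests on expectation alone. Given that compound 1 sits at 45500 nM, the step of a 1.2-fold higher number from compound 1 to compound 3 (0.08 log units; within the scatter) is expected to be small and possibly within the scatter. Compound 3 is therefore estimated to give 55000 nM in this assay, with a range from 18000 nM to 170000 nM.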

Compound 3, half-maximal inhibitory concentration: 20800 nM
The estimate for compound 3 lay 2.6-fold (0.42 log units) above the measured number; low and high end bracket the measured number.
By their numbers in this assay, from the lowest: compounds 2 and 3 (each within the scatter of the next); then compound 1.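

Replacing furan-2-yl with methyl on the carbonyl carbon gives in this assay a 2.2-fold lower number from compound 1 to compound 3 (0.34 log units; beyond the scatter), a modest change but one beyond the scatter, so this position does respond to what it carries. The furan-2-yl ring is therefore not required for the activity seen in this pair, since a single methyl carbon gives the lower number. Nothing at hand gives a reason for this step.

From the compounds shown here alone, two groups at this carbonyl carbon fix no trend, so it remains open whether the number follows the size of the group or the presence of a ring. A phenyl ring, a longer chain such as propyl, or an amine at this place would help to separate these readings.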